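Replacing the phenylsulfanyl group of compound 3

A few compounds are considered here, and "the series" means these few. Any claim that something is new, unique, unknown or untested is made for them only; others in the source may bear on it.

Values in a functional assay on the whole organism with Rattus norvegicus as the target; a lower number here means that less compound is needed, a higher number that more compound is needed for the effect:
Compound 1 `CCOC(=O)C(=O)Nc1nc(-c2ccc(OC)cc2)cs1`: about 10 mg/kg
Compound 2 `CCOC(=O)C(=O)Nc1nc(-c2ccc(Oc3ccccc3)cc2)cs1`: > 30 mg/kg, a limit
Compound 3 `CCOC(=O)C(=O)Nc1nc(-c2ccc(Sc3ccccc3)cc2)cs1`: > 3 mg/kg, a limit

Going by these compounds, compound 3 stands only at a limit, > 3 mg/kg, so its place among the others stays open. Compound 4 `CCOC(=O)C(=O)Nc1nc(-c2ccc(NC(=O)C(F)(F)F)cc2)cs1` carries ((trifluoromethyl)carbonyl)amino in place of phenylsulfanyl on an aromatic carbon. Among the measured compounds shown here, only one measured step can be read, an at least 3.0-fold higher number from compound 1 to compound 2 (0.47 log units; beyond the scatter), and it ends at a limit. The others, a step that the limit leaves unreadable from compound 1 to compound 3 and a step that the two limits leave unreadable from compound 2 to compound 3, give no size. The group entering compound 4 holds no ring, as does the methoxy of compound 1, which gives about 10 mg/kg, so a similar value is expected. The expected step is a step that the limit leaves unreadable from compound 3 to compound 4, though its true size stays loose. For compound 4 the estimated value is 10 mg/kg, with an expected range from 2.5 mg/kg to 40 mg/kg.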

Compound 4, dose for half-maximal effect: about 1 mg/kg
For compound 4 the middle estimate is 10-fold (1.00 log units) above the measured one; the whole stated range lies above it.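

In this assay, among the compounds shown here, the position tolerates more than the earlier compounds showed: a group with no ring, ((trifluoromethyl)carbonyl)amino, gives a 10-fold lower number from compound 1 to compound 4 (1.00 log units; beyond the scatter), so the absence of a ring alone does not set the value. Against the ring-bearing groups the change gives an at least 3.0-fold lower number from compound 3 to compound 4 (0.47 log units; beyond the scatter) and an at least 30-fold lower number from compound 2 to compound 4 (1.47 log units; beyond the scatter); both steps start from a limit, so their true sizes stay open. Nothing measured here accounts for the gain. It remains open whether the trifluoromethyl or the amide hydrogen matters, as neither an acetylamino group nor a free amine at this carbon appears among these compounds.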